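This account rests on a few compounds, and the source may have more. Where it says the series, first, only, none or still open, it means among the compounds named here.

Compound 3, `CCc1ccc(NC(=O)Nn2c(CC)nc3ccccc3c2=O)cc1`, was tested in a functional assay on the whole organism (strain albino) with Mus musculus as the target, at a dose of 100 mg/kg by the intraperitoneal route (a lower number here means less inhibition, a higher number more inhibition at the dose given (going by the name of the read-out)), where compound 3 gives 58%. Two related compounds are known in the same test. Compound 1, `CCc1ccc(NC(=O)Nn2c(-c3ccccc3)nc3ccccc3c2=O)cc1`, gives 61%, and compound 2, `Cc1cccc(NC(=O)Nn2c(-c3ccccc3)nc3ccccc3c2=O)c1`, gives 59%. The three numbers lie close together: a number 3 percentage points lower from compound 1 to compound 3 (within the scatter) and a number 2 percentage points lower from compound 1 to compound 2 (within the scatter), so compound 3 sits within the scatter of both of the others, and none of the three numbers can be called higher or lower than the rest; the inhibition in this assay is level across them.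

Compound 4, `CCc1nc2ccccc2c(=O)n1NC(=O)Nc1ccccc1C`, differs from compound 3 in one place: 2-methylphenyl in place of 4-ethylphenyl on an amide-type nitrogen. The group that leaves has eight heavy atoms and the group that enters has seven, both being a six-membered aromatic ring of carbon only, with no hydrogen-bond donors or acceptors on either.

Among the measured compounds shown here, the step that bears most directly on this change is the one from compound 1 to compound 2, where the same 4-ethylphenyl was swapped for a 3-methylphenyl on the amide-type nitrogen, and the read-out moved by only a number 2 percentage points lower from compound 1 to compound 2 (within the scatter). A methylphenyl in place of the ethylphenyl thus made no difference beyond the scatter, and the same is expected here: compound 4 is estimated to show a number 1 percentage points lower from compound 3 to compound 4 (within the scatter), which amounts to an expected 57% with a range from 45% to 69%.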

Compound 4, a percentage reported as inhibition, in the whole organism at one dose (the size of the read-out at that dose, not a potency): 54%
The estimate for compound 4 lay 3 percentage points above the measured number; low and high end bracket the measured number.
By their numbers in this assay, from the lowest: compounds 4, 3, 2 and 1 (each within the scatter of the next).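

With ethyl on the aromatic carbon of the core, replacing 4-ethylphenyl with 2-methylphenyl on the amide-type nitrogen gives, in this assay, a number 4 percentage points lower from compound 3 to compound 4 (within the scatter). The earlier step of this kind, a number 2 percentage points lower from compound 1 to compound 2 (within the scatter), involved 3-methylphenyl and a phenyl on that aromatic carbon, so the new step adds a second methylphenyl and a second version of the core, and again the change stays within the scatter. Across these four compounds, then, the three aryl groups on this nitrogen (4-ethylphenyl, 3-methylphenyl and 2-methylphenyl) cannot be told apart by this read-out, and no measurement available here offers an explanation for that level result.

On these data alone, what remains open is whether a more different group at this position, such as a phenyl ring carrying a carboxylic acid or an amine, or a saturated cyclohexyl ring, would shift the number beyond the scatter. As far as these compounds go, the read-out also gives the size of the inhibition at one dose rather than a potency, so it is still unknown whether these compounds would separate at other doses.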